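From compound 3 to its 4-chlorophenyl analogue

This account rests on a few compounds, and the source may have more. Where it says the series, first, only, none or still open, it means among the compounds named here.

In a functional assay on MCF7 cells (Homo sapiens) for antiproliferative activity, read by MTT assay, with a stated time of 48 h (on this read-out higher numbers stand for weaker inhibition and lower numbers for stronger inhibition), compound 1 `Fc1ccc2[nH]c(-c3cn(-c4ccccc4)nc3-c3ccccc3)nc2c1` gives 2430 nM and compound 2 `Cc1ccc2[nH]c(-c3cn(-c4ccccc4)nc3-c3ccccc3)nc2c1` gives 5940 nM.

Compound 3 `Cc1cc2nc(-c3cn(-c4ccccc4)nc3-c3ccccc3)[nH]c2cc1C` gives > 50000 nM, which is a limit and not a number. Compound 3 thus stands at the limit of > 50000 nM in this assay, at which 1 of the 3 values shown sits.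

Compound 4 `Cc1cc2nc(-c3cn(-c4ccccc4)nc3-c3ccc(Cl)cc3)[nH]c2cc1C` differs from compound 3 by chloro in place of hydrogen on an aromatic carbon, phenyl to 4-chlorophenyl, para to a large group: chloro in place of hydrogen on an aromatic carbon.

Two measured steps are available, and both bear only loosely on this change. Methyl in place of fluoro gave a 2.4-fold higher number from compound 1 to compound 2 (0.39 log units; beyond the scatter), a modest step. Methyl in place of hydrogen gave an at least 8.4-fold higher number from compound 2 to compound 3 (0.92 log units; beyond the scatter), a step of at least modest size. Among the measured compounds shown here, neither step alters a phenyl group, and no chloro compound has been measured. For the measured compounds named here, the step to compound 2 is the only guide to a halogen, with fluoro in compound 1 at 2430 nM giving the lower number. A modest move towards a lower number is therefore expected, though a result at the limit remains quite possible.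

The expected change is an at least 1.6-fold lower number from compound 3 to compound 4 (0.22 log units; that floor lies within the scatter). Compound 4 is estimated at 30000 nM, with an expected range from 7000 nM to 50000 nM.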

Compound 4, half-maximal inhibitory concentration: 13000 nM
Beside the measured number, compound 4's estimate is 2.3-fold (0.36 log units) above it; the range from low to high includes it.
By their numbers in this assay, from the lowest: compound 1; then compound 2; then compound 4. At a limit, above all of these: compound 3.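

In this assay, among the compounds shown here, chloro in place of hydrogen gives an at least 3.8-fold lower number from compound 3 to compound 4 (0.58 log units; beyond the scatter), so a single added atom on this phenyl group moves the read-out, which the earlier steps, leaving both phenyl groups unchanged, could not show. Compound 4 gives 13000 nM, so the two methyl groups shared with compound 3 do not by themselves rule out a measured number. The value of compound 3 is a limit and not a number, so the step gives only a floor and its full size remains unknown: the limit of > 50000 nM in this assay, at which 1 of the 4 values shown sits.

Going by these compounds, it remains open whether this change is specific to chloro, or whether fluoro, methoxy, an amine or a carboxylic acid on the same carbon would also give a lower number. On these data alone, it is also open whether phenyl to 4-chlorophenyl gives a step of similar size on the cores of compound 1 and compound 2, and whether the same change on the other phenyl group would move the read-out at all.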